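The source may report more compounds than this note shows. Statements on the series, on what has been measured and on what is new or still open speak of the compounds shown alone.

In a functional assay on HT-29 cells (Homo sapiens) for inhibition, read by sulforhodamine B assay, with a stated time of 72 h (a higher number here means a weaker inhibitor, a lower number a stronger inhibitor), compound 1 `COc1cc(N2C(=O)CC2c2ccc(SC)cc2)cc(OC)c1OC` gives 108 nM, the middle of three measured numbers. Compound 2 `COc1ccc(C2C(O)C(=O)N2c2cc(OC)c(OC)c(OC)c2)cc1` gives a lower 12 nM, and compound 3 `CCSc1ccc(C2C(Oc3ccccc3)C(=O)N2c2cc(OC)c(OC)c(OC)c2)cc1` gives a higher 632 nM. Both gaps from compound 1 lie beyond the usual scatter. Compound 4 `C=CC1C(=O)N(c2cc(OC)c(OC)c(OC)c2)C1c1ccc(SC)cc1` differs from compound 1 by one change: vinyl in place of hydrogen on a saturated ring carbon. For the measured compounds named here, no measured pair shows this change alone. Compound 2 at 12 nM and compound 3 at 632 nM also carry a group on that ring carbon, but they differ elsewhere too, so they give only a loose guide. A modest move towards stronger inhibition is expected, with the estimated change being a 2.2-fold lower number from compound 1 to compound 4 (0.33 log units; beyond the scatter). Compound 4 is estimated at 50 nM, within an expected range of 10 nM to 250 nM.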

Compound 4, half-maximal inhibitory concentration: 113 nM
Estimate against measurement, compound 4: 2.3-fold (0.35 log units) below; measured number inside the range.
By their numbers in this assay, from the lowest: compound 2; then compounds 1 and 4 (each within the scatter of the next); then compound 3.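

In this assay, vinyl in place of hydrogen on the saturated ring carbon gives a 1.0-fold higher number from compound 1 to compound 4 (0.02 log units; within the scatter) as a step within the scatter. For the compounds shown here, this is the first comparison at this position in which only one place differs, and it shows that this ring carbon can carry vinyl while the two numbers remain indistinguishable. Nothing available explains this result. On these data alone, whether the same holds for an amine, a carboxylic acid or a longer chain such as propyl on this carbon stays open. One vinyl step cannot show how other groups there would behave.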